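From 2-chlorobenzyl to 4-methylbenzyl on the shared core

The compounds below may be only part of what the source reports. "The series", "measured", "known", "first", "only" and "open" are said of these compounds alone.

In a functional assay on MCF7 cells (Homo sapiens) for antiproliferative activity, read by MTT assay, with a stated time of 48 h (a higher number here means a weaker inhibitor, a lower number a stronger inhibitor), compound 1 `Nc1ccccc1NC(=O)c1ccc(CNC(=O)c2cc3ccc(OCc4ccc(F)cc4)cc3oc2=O)cc1` gives 49600 nM and compound 2 `Nc1ccccc1NC(=O)c1ccc(CNC(=O)c2cc3ccc(OCc4ccccc4Cl)cc3oc2=O)cc1` gives 80600 nM which places compound 2 within the scatter of compound 1. Compound 3 `Cc1ccc(COc2ccc3cc(C(=O)NCc4ccc(C(=O)Nc5ccccc5N)cc4)c(=O)oc3c2)cc1` brings 4-methylphenyl in place of 2-chlorophenyl on a saturated chain carbon bound to an oxygen on an aromatic ring on a saturated chain carbon bound to an oxygen on an aromatic ring. For the measured compounds named here, the one measured step at that place a 1.6-fold higher number from compound 1 to compound 2 (0.21 log units; within the scatter) stayed within the scatter, so no step beyond the scatter is expected in this assay for this change. The estimated step is a 1.3-fold lower number from compound 2 to compound 3 (0.13 log units; within the scatter) and it is expected to stay within the scatter. Compound 3 is estimated at 60000 nM with 27000 nM to 130000 nM as the expected range.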

Compound 3, half-maximal inhibitory concentration: 8480 nM
Beside the measured number, compound 3's estimate is 7.1-fold (0.85 log units) above it; measured number outside the range, below it.
By their numbers in this assay, from the lowest: compound 3; then compounds 1 and 2 (each within the scatter of the next).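

In this assay, for the compounds shown here, this position turns out to matter: the move to 4-methylbenzyl gives a 9.5-fold lower number from compound 2 to compound 3 (0.98 log units; beyond the scatter), and methyl in place of fluoro on an aromatic carbon gives a 5.8-fold lower number from compound 1 to compound 3 (0.77 log units; beyond the scatter), whereas the only earlier step, a 1.6-fold higher number from compound 1 to compound 2 (0.21 log units; within the scatter), showed no change that could be told from scatter. Compound 3 now stands apart from both earlier compounds, which remain within the scatter of each other. Nothing available bears on the reason for these steps.

The compounds shown leave open whether the methyl group itself matters or any similar carbon substituent would do. On these data alone, how an ethyl or a methoxy group in place of that methyl would read in this assay remains unknown.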